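Nitro in place of carboxy on the tetrafluoropropyl ether

The source may hold more compounds than are shown below. What is called first, only, known or untested is meant among the compounds shown, and "the series" means these compounds.

Three compounds of the series have numbers in an assay on cells for activation of Cystic fibrosis transmembrane conductance regulator (Homo sapiens), read by fluorescence, with stated times of 10 min and 12 s; a higher number here means that more compound is needed for the effect, a lower number that less compound is needed. Compound 1 `CCN(CC)c1nc(Nc2cccc(C(=O)O)c2)nc(OC(C(F)(F)F)C(F)(F)F)n1` gives 160 nM in this assay. Compound 2 `CCN(CC)c1nc(Nc2ccc3ncsc3c2)nc(OC(C(F)(F)F)C(F)(F)F)n1` gives 50 nM, the step being a 3.2-fold lower number from compound 1 to compound 2 (0.51 log units; beyond the scatter). Compound 3 `CCN(CC)c1nc(Nc2cccc(C(=O)O)c2)nc(OCC(F)(F)C(F)F)n1` gives 500 nM, the step being a 3.1-fold higher number from compound 1 to compound 3 (0.49 log units; beyond the scatter). On the numbers shown compound 3 stands highest of the three, with compound 1 nearest and compound 2 furthest from it.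

Compound 4 `CCN(CC)c1nc(Nc2cccc([N+](=O)[O-])c2)nc(OCC(F)(F)C(F)F)n1` keeps the ether of compound 3 and differs at the aryl group: nitro in place of carboxy on an aromatic carbon. For the measured compounds named here, no measured step exchanges carboxy for nitro. Going by the values given here, the one step that touches the same position, from compound 1 to compound 2, replaced the whole 3-carboxyphenyl and brought a modest lower number, so the carboxy is not required for the effect. The step from compound 1 to compound 3 concerns the ether and does not bear on this change. A step of modest size is therefore expected for compound 4 in this assay, most likely towards a lower number or none beyond the scatter, and its number is estimated at 300 nM, within 100 nM to 900 nM. The expected step is a 1.7-fold lower number from compound 3 to compound 4 (0.22 log units; within the scatter).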

Compound 4, half-maximal effective concentration: 1200 nM
The estimate for compound 4 lay 4.0-fold (0.60 log units) below the measured number; measured number above the stated range.
By their numbers in this assay, from the lowest: compound 2; then compound 1; then compound 3; then compound 4.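

In this assay the exchange of carboxy for nitro gives a 2.4-fold higher number from compound 3 to compound 4 (0.38 log units; beyond the scatter) on the tetrafluoropropyl ether, with the ring, the place of the group and the rest of the molecule held constant. The step is modest but beyond the scatter, and the carboxy stands on the side of the lower number, so the earlier finding that the 3-carboxyphenyl can be replaced does not extend to any group at this position: the outcome depends on what enters, and 3-nitrophenyl does not keep the number of 3-carboxyphenyl. Nothing measured on these compounds accounts for the direction of this step.

On these data alone, whether carboxy and nitro keep this order on the 2,2,2-trifluoro-1-(trifluoromethyl)ethyl ether remains open, as does whether the 1,3-benzothiazol-6-yl group of compound 2 would hold its advantage on the tetrafluoropropyl ether. Also open, as far as these compounds go, is how a primary amide, a nitrile or an amine in the same place on the aromatic ring would stand against carboxy and nitro.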